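Phenyl Instead of Methoxyphenylamino: an Expected Value

This account rests on a few compounds, and the source may have more. Where it says the series, first, only, none or still open, it means among the compounds named here.

Compound 1 `N#CC1=C(NCC(=O)N2CCOCC2)N(c2ccccc2)C(=O)N2CCCCC(N3CCCC3)C12` gives 69.8% in a functional assay on the whole organism (strain albino) for inhibition, with Rattus norvegicus as the target, read by paw edema, with stated times of 1 h and 2 h, at a dose of 20 mmol/kg by the intraperitoneal route; a lower number here means less inhibition, a higher number more inhibition at the dose given (going by the name of the read-out).
Compound 2 `N#CC1=C(NCC(=O)O)N(c2ccccc2)C(=O)N2CCCCC(N3CCCC3)C12` gives 81.7% in this assay.
Compound 3 `COc1ccc(N/C=N/C2=C(C#N)C3C(N4CCCC4)CCCCN3C(=O)N2c2ccccc2)cc1` gives 37.2% in this assay.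

Compound 3 stands lowest of the three numbers. The step of a number 32.6 percentage points lower from compound 1 to compound 3 (beyond the scatter) and the step of a number 44.5 percentage points lower from compound 2 to compound 3 (beyond the scatter) both go down, each beyond the scatter, while the step of a number 11.9 percentage points higher from compound 1 to compound 2 (beyond the scatter) is modest. Compound 4 `N#CC1=C(/N=C/c2ccccc2)N(c2ccccc2)C(=O)N2CCCCC(N3CCCC3)C12` has not yet been measured. It differs from compound 3 in one place: phenyl in place of (4-methoxyphenyl)amino on a carbon with a double bond to nitrogen.

For the measured compounds named here, none of the measured steps touches this part of the structure, so no step bears on it directly. The two large drops that lead to compound 3 came when the group on the double-bonded ring carbon was exchanged for one with a six-membered aromatic ring of carbon only, and compound 4 keeps such a ring at that place. The estimated step is a number 4.8 percentage points higher from compound 3 to compound 4 (within the scatter), expected to stay within the scatter, with no clear direction. Compound 4 is therefore expected to give about 42% in this assay, with an estimated range from 25% to 60%.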

Compound 4, a percentage reported as inhibition, in the whole organism at one dose (the size of the read-out at that dose, not a potency): 75.9%
Compound 4: middle estimate off by 33.9 percentage points, on the low side, outside the stated range (above it).
By their numbers in this assay, from the lowest: compound 3; then compounds 1, 4 and 2 (each within the scatter of the next, the first and the last beyond it).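

In this assay, for the compounds shown here, the group on the carbon with a double bond to nitrogen turns out to matter: exchanging (4-methoxyphenyl)amino for phenyl gives a number 38.7 percentage points higher from compound 3 to compound 4 (beyond the scatter) as a large step, at a place that no earlier pair of compounds had touched. The other two new steps, a number 5.8 percentage points lower from compound 2 to compound 4 (within the scatter) and a number 6.1 percentage points higher from compound 1 to compound 4 (within the scatter), both lie within the scatter, so with phenyl at this place the low number seen for compound 3 is gone. A six-membered aromatic ring of carbon only in the group on the double-bonded ring carbon is therefore not tied to a low number on its own, since the group in compound 4 holds such a ring as well.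

The change removes the amino link and the methoxy group together, so the shown compounds cannot say which of the two goes with the low number; a plain phenylamino group or a 4-methoxyphenyl group at the same carbon would separate them. No measurement at hand explains the size of this step.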